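The source may report more compounds than this note shows. Statements on the series, on what has been measured and on what is new or still open speak of the compounds shown alone.

Working notes on the series, all in a functional assay on VCaP cells (Homo sapiens) for antiproliferative activity, read by propidium iodide staining, with a stated time of 96 h; on this read-out lower numbers stand for stronger inhibition and higher numbers for weaker inhibition. Compound 1 `CC(O)(COc1cccc(C(F)(F)F)c1)C(=O)Nc1ccc(S(F)(F)(F)(F)F)cc1` gives 24700 nM, compound 2 `CC(O)(COc1ccccc1C(F)(F)F)C(=O)Nc1ccc(S(F)(F)(F)(F)F)cc1` gives 3100 nM, and compound 3 `CC(O)(COc1ccc(C#N)cc1)C(=O)Nc1ccc(S(F)(F)(F)(F)F)cc1` gives 100000 nM, the highest of the three numbers. Compound 4 `CC(O)(COc1ccc(C#N)c(F)c1)C(=O)Nc1ccc(S(F)(F)(F)(F)F)cc1` carries fluoro in place of hydrogen on an aromatic carbon of compound 3: fluoro in place of hydrogen on an aromatic carbon. Going by the values given here, no measured step adds fluoro, so only the aryl swaps bear on it: a 4.0-fold higher number from compound 1 to compound 3 (0.61 log units; beyond the scatter), a 32-fold higher number from compound 2 to compound 3 (1.51 log units; beyond the scatter) and an 8.0-fold lower number from compound 1 to compound 2 (0.90 log units; beyond the scatter). These range from modest to large, but each replaces a whole substituted aryl group, so a modest step to a lower number is expected, with no firm support for its direction. For compound 4 the estimated value is 50000 nM, with an expected range of 15000 nM to 100000 nM. The expected change is a 2.0-fold lower number from compound 3 to compound 4 (0.30 log units; within the scatter).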

Compound 4, half-maximal inhibitory concentration: 100000 nM
Compound 4: middle estimate off by 2.0-fold (0.30 log units), on the low side; the measured number falls inside the stated range.
By their numbers in this assay, from the lowest: compound 2; then compound 1; then compounds 3 and 4 (each within the scatter of the next).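

In this assay, fluoro in place of hydrogen ortho to the cyano group gives no change at the digits printed from compound 3 to compound 4 (within the scatter), so this single atom leaves the number where it stood. The 4-cyano-3-fluorophenyl group stays as far from the trifluoromethyl compounds as 4-cyanophenyl did, with a 32-fold higher number from compound 2 to compound 4 (1.51 log units; beyond the scatter) and a 4.0-fold higher number from compound 1 to compound 4 (0.61 log units; beyond the scatter). No supporting measurement bears on this result.

Going by these compounds, whether chloro, methoxy or an amine at the same position would shift the number remains open. So does the effect of fluoro on the 2-(trifluoromethyl)phenyl group of compound 2, the lowest number here.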